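Inverting the sulfur stereocentre of compound 1

The source may report more compounds than this note shows. Statements on the series, on what has been measured and on what is new or still open speak of the compounds shown alone.

Measured so far in an ADME assay on microsomes from liver (Mus musculus, strain CD1) for metabolic stability, with a stated time of 1 h; a higher number here means that more of the compound is left, a lower number that less of the compound is left:
- compound 1 (`O=[N+]([O-])c1cn2c(n1)[S@@+]([O-])C[C@@H](OCc1ccc(OC(F)(F)F)cc1)C2`) at 93%
- compound 2 (`O=[N+]([O-])c1cn2c(n1)[S+]([O-])CC(OCc1ccc(-c3ccc(OC(F)(F)F)cc3)cn1)C2`) at 72%

Compound 1 stands highest of the two numbers at 93% and compound 2 lies at 72%, lower by a gap beyond the usual scatter. Compound 3 (`O=[N+]([O-])c1cn2c(n1)[S@+]([O-])C[C@@H](OCc1ccc(OC(F)(F)F)cc1)C2`) differs from compound 1 as follows: the two compounds have the same atoms and bonds and differ only in configuration as drawn: 1 of 2 stereo elements differ; a stereocentre at a sulfur is drawn S in compound 1 and R in compound 3. The element concerned is a stereocentre at a sulfur, drawn S in compound 1 and R in compound 3. Within the data shown here, no measured pair shows a change of this kind, so the expectation has no direct precedent. With compound 1 at 93% there is little room upward, so a small downward move or none beyond the scatter is expected. The expected move is a number 5 percentage points lower from compound 1 to compound 3 (within the scatter) in this assay as a working figure. For compound 3 the estimate is 88% with an expected range from 68% to 100% on this basis.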

Compound 3, percent of the compound remaining: 96%
Beside the measured number, compound 3's estimate is 8 percentage points below it; the range from low to high includes it.
By their numbers in this assay, from the lowest: compound 2; then compounds 1 and 3 (each within the scatter of the next).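

Before this pair, the series held no comparison at the sulfur stereocentre, so the position had no precedent. In this assay, drawing this stereocentre S or R makes no difference that can be told from the scatter, with a number 3 percentage points higher from compound 1 to compound 3 (within the scatter). The comparison rests on this single stereo element, with nothing entering or leaving the structure: the fact that compounds 1 and 3 differ only in the configuration as drawn

On these data alone, compound 1 gives 93% and compound 3 gives 96%, both close to the top of the read-out, so a larger effect of the sulfur configuration in a less stable compound remains open. Also open, as far as these compounds go, are the role of the second stereo element and whether the same holds for a compound of this series carrying an amine or a carboxylic acid.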